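The source may report more compounds than this note shows. Statements on the series, on what has been measured and on what is new or still open speak of the compounds shown alone.

Measured compounds:
compound 1, `Cc1n[nH]c(C(=O)O)c1Cc1ccc(Oc2ccccc2)cc1` — 10%
compound 2, `Cc1n[nH]c(C(=O)O)c1Cc1cc2ccccc2s1` — 8%
compound 3, `Cc1n[nH]c(C(=O)O)c1CCc1ccc(F)cc1` — 5%

All three share the same core and were tested in an assay on isolated protein for inhibition of 2-Hydroxyacid oxidase 2 (Homo sapiens), tested at 1 uM; a higher number here means a stronger effect of the compound at the concentration tested, a lower number a weaker effect. Compound 1 gives 10%, the top figure of the three, but compound 2 with 8% and compound 3 with 5% both lie within the usual scatter of it, so the three cannot be told apart on these numbers; each shows only a small effect at this concentration.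

Compound 4, `Cc1n[nH]c(C(=O)O)c1Cc1ccc(C(=O)O)cc1`, has not yet been measured in this assay. It differs from compound 1 in one place: carboxy in place of phenoxy on an aromatic carbon. The phenoxy group leaves and a carboxy group enters on an aromatic carbon, para to a large group.

Within the data shown here, no measured pair shows what a change of this kind does here, and all three measured compounds sit low and close together. The step from compound 1 to compound 4 in this assay is therefore expected to be small, a number 2 percentage points lower from compound 1 to compound 4 (within the scatter), in no particular direction beyond the scatter. Compound 4 is estimated at 8%, with a range from 0% to 20%.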

Compound 4, a percentage reported as inhibition, at one concentration (the size of the read-out at that concentration, not a potency): 3%
For compound 4 the middle estimate is 5 percentage points above the measured one; the measured number falls inside the stated range.
By their numbers in this assay, from the lowest: compounds 4, 3, 2 and 1 (each within the scatter of the next).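

In this assay, putting a carboxy group in place of the phenoxy group on the aromatic carbon para to a large group gives a number 7 percentage points lower from compound 1 to compound 4 (within the scatter). Among these compounds, this is the first measured change at this position, and it replaces a group holding a six-membered aromatic ring with a smaller group that has no ring. Even this large change in the group leaves the read-out within the scatter, so the phenoxy ring is not shown to matter in this low range, and no measurement at hand bears on why.

From the compounds shown here alone, it remains open whether any group at this position can produce a clear effect at the concentration tested. An amine or a methoxy group on the same aromatic carbon would extend the comparison, though a read-out at a single concentration gives no potency.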